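Ring swaps on a series that shows no cytotoxicity

A few compounds are considered here, and "the series" means these few. Any claim that something is new, unique, unknown or untested is made for them only; others in the source may bear on it.

Compound 1 `CC(C)N(Cc1cccc(OCCCCCC(=O)O)c1)C(=O)c1ccc(-c2cccc3ccccc23)cc1`: in an ADME assay on HepG2 cells (Homo sapiens) for cytotoxicity, read by CellTiter-Glo and resazurin assay, with a stated time of 72 h (on this read-out lower numbers stand for an effect already at smaller amounts and higher numbers for an effect only at larger amounts of compound), compound 1 sits at a limit, > 26000 nM.
Compound 2 `CC(C)N(Cc1cccc(OCCCCCC(=O)O)c1)C(=O)c1ccc(-c2ccoc2)cc1`: in this assay compound 2 sits at a limit, > 26000 nM.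
Compound 3 `CC(C)N(Cc1cccc(OCCCCCC(=O)O)c1)C(=O)c1ccc(-c2ccsc2)cc1`: in this assay compound 3 sits at a limit, > 26000 nM.

Compound 3 therefore stands where all three measured compounds stand, at the limit of > 26000 nM in this assay, at which 3 of the 3 values shown sit, with no number of its own. Compound 4 `CC(C)N(Cc1cccc(OCCCCCC(=O)O)c1)C(=O)c1ccc(-c2ccc3c(c2)OCCO3)cc1` differs from it by 2,3-dihydro-1,4-benzodioxin-6-yl in place of thiophen-3-yl on an aromatic carbon. The measured steps that bear on this are a step that the two limits leave unreadable from compound 1 to compound 2, a step that the two limits leave unreadable from compound 1 to compound 3 and a step that the two limits leave unreadable from compound 2 to compound 3, none of which can be sized. No step beyond the scatter is therefore expected in this assay, in either direction. Compound 4 is expected to give 30000 nM, with a range from 15000 nM to 60000 nM, most likely again as a limit. The step from compound 3 to compound 4 is estimated as a step that the limit leaves unreadable from compound 3 to compound 4.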

Compound 4, half-maximal effective concentration: > 21900 nM
Compound 4 gave a limit, no number; the forecaster's own chance of this, stated with the estimate: 80%; the middle value lies beyond the limit too.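

Within the data shown here, compound 1, compound 2, compound 3 and compound 4 all give limits, and no step among them can be read. The compounds shown leave open at what concentration, if any, each would reach its half-maximal effect in this assay.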